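Methylphenyl Placement on the Triazole and OVCAR-3 Activity

A few compounds are considered here, and "the series" means these few. Any claim that something is new, unique, unknown or untested is made for them only; others in the source may bear on it.

Compound 1 `Cc1ccccc1-n1cc(-c2ccccc2NS(=O)(=O)c2c[nH]c(=O)[nH]c2=O)nn1` gives 6550 nM in a functional assay on OVCAR-3 cells (Homo sapiens) for antiproliferative activity, read by MTT assay, with a stated time of 24 h; a higher number here means a weaker inhibitor, a lower number a stronger inhibitor.
Compound 2 `Cc1cccc(-n2cc(-c3ccccc3NS(=O)(=O)c3c[nH]c(=O)[nH]c3=O)nn2)c1` gives 3150 nM in this assay.
Compound 3 `Cc1ccccc1-n1cc(-c2ccc(NS(=O)(=O)c3c[nH]c(=O)[nH]c3=O)cc2)nn1` gives 7310 nM in this assay.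

In this assay the change 3-methylphenyl in place of 2-methylphenyl on an aromatic nitrogen produced a 2.1-fold lower number from compound 1 to compound 2 (0.32 log units; beyond the scatter). Compound 3 and compound 1 lie within the usual scatter of each other, while compound 2 shows a lower number than compound 3. How the cores of compound 1 and compound 3 differ is not broken down here.

Compound 4 `Cc1cccc(-n2cc(-c3ccc(NS(=O)(=O)c4c[nH]c(=O)[nH]c4=O)cc3)nn2)c1` has not yet been measured. Among the measured compounds shown here, it differs from compound 3 by 3-methylphenyl in place of 2-methylphenyl on an aromatic nitrogen, the same change, at the same place, as the one from compound 1 to compound 2. Because that earlier change gave a 2.1-fold lower number from compound 1 to compound 2 (0.32 log units; beyond the scatter), a step of similar size is expected here, estimated as a 2.1-fold lower number from compound 3 to compound 4 (0.32 log units; beyond the scatter). Compound 4 is therefore expected to give about 3500 nM in this assay, with a likely range from 1800 nM to 7000 nM.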

Compound 4, half-maximal inhibitory concentration: 7490 nM
The estimate for compound 4 lay 2.1-fold (0.33 log units) below the measured number, and the stated range ends below it.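

In this assay, 3-methylphenyl in place of 2-methylphenyl on the core of compound 3 gave a 1.0-fold higher number from compound 3 to compound 4 (0.01 log units; within the scatter), so this pair shows no separation, unlike the pair on the core of compound 1. Even so, the two steps cannot be told apart: the same change on two cores in this assay, a 2.1-fold lower number (0.32 log units; beyond the scatter) from compound 1 to compound 2 and a 1.0-fold higher number (0.01 log units; within the scatter) from compound 3 to compound 4, 2.1-fold (0.33 log units) apart, within the scatter of two such steps. With one pair on each core, the data do not show that the change carries from one core to the other, nor that its outcome depends on the core.

The compounds shown leave open how a methoxy group, a chlorine atom or an ethyl chain in place of the methyl would behave on either core. As far as these compounds go, whether an amine there would follow either step also remains open.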